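Swapping the Outer Aryl Ring of a Fatty Acid Receptor Agonist

A few compounds are considered here, and "the series" means these few. Any claim that something is new, unique, unknown or untested is made for them only; others in the source may bear on it.

Measured so far:
compound 1 `O=C(O)C[C@@H]1C[C@H](C(F)(F)F)CN1c1ccc(Oc2ccccc2C(F)(F)F)cc1`, 1300 nM
compound 2 `O=C(O)C[C@@H]1C[C@H](C(F)(F)F)CN1c1ccc(Oc2ccccc2OC(F)(F)F)cc1`, 740 nM

In a functional assay on cells for agonist activity at Free fatty acid receptor 1 (Mus musculus), read by FLIPR and calcium flux, with a stated time of 100 s (a higher number here means that more compound is needed for the effect, a lower number that less compound is needed), compound 1 gives 1300 nM, the highest of the two numbers; its closest neighbour is compound 2, which gives 740 nM. Within the data shown here, the one measured step is a 1.8-fold lower number from compound 1 to compound 2 (0.24 log units; within the scatter), so these two compounds cannot be told apart.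

Compound 3 `COc1ccc(Oc2ccc(N3C[C@@H](C(F)(F)F)C[C@H]3CC(=O)O)cc2)c(C)c1` has not yet been measured. It differs from compound 1 in one place: 4-methoxy-2-methylphenyl in place of 2-(trifluoromethyl)phenyl on an oxygen on an aromatic ring. The measured step from compound 1 to compound 2 only shows that exchanging one small fluorinated group for another on the outer ring left the number unchanged within the scatter; it says nothing about replacing that ring's substituents with a methyl and a methoxy. Among the measured compounds shown here, with no closer precedent, compound 3 is expected to land near compound 1, with the step of a 1.3-fold lower number from compound 1 to compound 3 (0.11 log units; within the scatter) not clearly beyond the scatter. The estimate for compound 3 is 1000 nM, within a range of 300 nM to 3500 nM.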

Compound 3, half-maximal effective concentration: 170 nM
The estimate for compound 3 lay 5.9-fold (0.77 log units) above the measured number; measured number below the stated range.
By their numbers in this assay, from the lowest: compound 3; then compounds 2 and 1 (each within the scatter of the next).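

In this assay the group on the oxygen turns out to be a place where the number can move clearly beyond the scatter: 4-methoxy-2-methylphenyl in place of 2-(trifluoromethyl)phenyl gives a real drop (a 7.6-fold lower number from compound 1 to compound 3 (0.88 log units; beyond the scatter)). The earlier pair, which only exchanged one fluorinated group for another, showed no such movement, so this position is not indifferent to what it carries. No measurement at hand says why the number fell.

Going by these compounds, the change brings in a methyl and a methoxy together, and no compound here carries only one of them, so it remains open which of the two accounts for the step, or whether both are needed. On these data alone, whether an amine or a longer ether chain in place of the methoxy would keep the lower number is also open.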